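This account rests on a few compounds, and the source may have more. Where it says the series, first, only, none or still open, it means among the compounds named here.

In a functional assay on Bel-7402 cells (Homo sapiens) for cytotoxicity, read by MTT assay (a lower number here means a stronger inhibitor, a higher number a weaker inhibitor), compound 2 `CCn1cc(C(=O)Nc2ccc(Cl)cn2)c(=O)c2cc(F)c(N3CCNC(C)C3)c(F)c21` gives 4900 nM, the middle of the three measured numbers. Compound 1 `CCn1cc(-c2nc3ccc([N+](=O)[O-])cc3o2)c(=O)c2cc(F)c(N3CCNC(C)C3)c(F)c21` gives 1600 nM and compound 3 `CCn1cc(C(=O)Nc2ccc(C)c([N+](=O)[O-])c2)c(=O)c2cc(F)c(N3CCNC(C)C3)c(F)c21` gives 29100 nM. Compound 4 `CCn1cc(C(=O)Nc2ccc(C(C)=O)cc2)c(=O)c2cc(F)c(N3CCNC(C)C3)c(F)c21` differs from compound 2 by 4-acetylphenyl in place of 5-chloropyridin-2-yl on an amide-type nitrogen. Going by the values given here, only one measured step bears on this place: a 5.9-fold higher number from compound 2 to compound 3 (0.77 log units; beyond the scatter), with 4-methyl-3-nitrophenyl entering, which is modest but beyond the scatter. On that single precedent, a smaller step in the same direction is expected in this assay. The estimated step is a 2.2-fold higher number from compound 2 to compound 4 (0.35 log units; beyond the scatter). For compound 4 the expected value is 11000 nM, with an estimated range of 3500 nM to 32000 nM.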

Compound 4, half-maximal inhibitory concentration: > 50000 nM
Compound 4 was reported as a limit (the forecaster's own chance of this, stated with the estimate: 5%); at least 4.5-fold (0.65 log units) between middle value and limit.
By their numbers in this assay, from the lowest: compound 1; then compound 2; then compound 3. At a limit, above all of these: compound 4.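

At the amide-type nitrogen, both carbon-only aryl groups now lie higher than 5-chloropyridin-2-yl in this assay, the new one with an at least 10-fold higher number from compound 2 to compound 4 (1.00 log units; beyond the scatter). Against 4-methyl-3-nitrophenyl, the change gives an at least 1.7-fold higher number from compound 3 to compound 4 (0.23 log units; that floor lies within the scatter), a floor that sets no order between these two groups. Compound 4 is a limit, not a number: the limit of > 50000 nM in this assay, at which 1 of the 4 values shown sits.

On these data alone, the full size of the step to compound 4 remains open, as does whether the ring nitrogen or the chlorine of compound 2 accounts for the difference. An unsubstituted phenyl or an unsubstituted pyridinyl on the same amide would separate the two.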